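The source may report more compounds than this note shows. Statements on the series, on what has been measured and on what is new or still open speak of the compounds shown alone.

The measured compounds:
Compound 1, `Cc1nc(C)c(/C=C/C(=O)/C=C/c2ccccc2O)nc1C`, gives 3900 nM in a functional assay on A549/CDDP cells (Homo sapiens) for antiproliferative activity, read by MTT assay, with a stated time of 72 h; a lower number here means a stronger inhibitor, a higher number a weaker inhibitor.
Compound 2, `COc1cccc(/C=C/C(=O)/C=C/c2nc(C)c(C)nc2C)c1O`, gives 2190 nM in this assay.
Compound 3, `COc1ccc(/C=C/C(=O)/C=C/c2nc(C)c(C)nc2C)cc1`, gives 3610 nM in this assay.

Compound 2 differs from compound 1 in one place: methoxy in place of hydrogen on an aromatic carbon. That change gave a 1.8-fold lower number from compound 1 to compound 2 (0.25 log units; within the scatter) in this assay. Compound 3 has a different core; how its core differs from that of compound 1 is not broken down here, and the two values lie within the scatter of each other. Compound 4, `COc1ccc(/C=C/C(=O)/C=C/c2nc(C)c(C)nc2C)c(OC)c1`, is not yet measured. It differs from compound 3 by methoxy in place of hydrogen on an aromatic carbon. For the measured compounds named here, this is the same kind of change as the one from compound 1 to compound 2, but the surroundings differ: in compound 2 the new group sits ortho to a hydroxy group and meta to a large group, whereas in compound 4 it sits ortho to a large group and meta to a methoxy group. Going by the values given here, the single earlier example, a 1.8-fold lower number from compound 1 to compound 2 (0.25 log units; within the scatter), stayed within the scatter, so a similarly small step is expected here: a 1.4-fold lower number from compound 3 to compound 4 (0.14 log units; within the scatter). Compound 4 is therefore estimated at 2600 nM in this assay, with a likely range from 1200 nM to 6000 nM.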

Compound 4, half-maximal inhibitory concentration: 2850 nM
For compound 4 the middle estimate is 1.1-fold (0.04 log units) below the measured one; low and high end bracket the measured number.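

On the core of compound 3, methoxy in place of hydrogen on an aromatic carbon gave a 1.3-fold lower number from compound 3 to compound 4 (0.10 log units; within the scatter) in this assay and so matched the small step seen earlier. Set side by side, the two examples cannot be told apart: the same change on two cores in this assay, a 1.8-fold lower number (0.25 log units; within the scatter) from compound 1 to compound 2 and a 1.3-fold lower number (0.10 log units; within the scatter) from compound 3 to compound 4, 1.4-fold (0.15 log units) apart, within the scatter of two such steps. In these two pairs the change therefore carries over from one core to the other as a small step, but this does not show that methoxy truly alters the number on either core, and two pairs with the new group in different surroundings cannot establish a rule for the whole series.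

Methoxy is the only entering group in these steps, so it remains open whether an amine, a carboxylic acid, fluorine or a longer alkoxy chain in the same place would give a step large enough to stand clear of the scatter. From the compounds shown here alone, it also remains open whether methoxy itself would do so at other places on the ring.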